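The source may hold more compounds than are shown below. What is called first, only, known or untested is meant among the compounds shown, and "the series" means these compounds.

Measured so far in a toxicity assay on the whole organism (J774 cells) for cytotoxicity, with Mus musculus as the target, read by MTT assay, with a stated time of 24 h, tested at 30 uM; on this read-out lower numbers stand for a stronger effect and higher numbers for a weaker effect at the one concentration tested:
compound 1 `CCCCCCCCCO[C@@H]1[C@@H](N)[C@@H](OC[C@H](O)CN=[N+]=[N-])O[C@H](CN)[C@H]1OCCCCCCCCC` gives 5.9%
compound 2 `NC[C@H]1O[C@H](O[C@H]2[C@H](O)[C@@H](O)[C@H](N)C[C@@H]2N)[C@H](N)[C@@H](OCCCc2ccc3ccccc3c2)[C@@H]1OCCCc1ccc2ccccc2c1` gives 66.9%
compound 3 `C=CCO[C@H]1O[C@H](CN)[C@@H](OCCCc2ccc3ccccc3c2)[C@H](OCCCc2ccc3ccccc3c2)[C@H]1N` gives 7%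

Compound 1 holds the lowest of the three numbers, though compound 3 lies within the scatter of it; only compound 2 stands apart, beyond the scatter. Within the data shown here, the one measured step, a number 59.9 percentage points lower from compound 2 to compound 3 (beyond the scatter), is large but concerns a different change and so does not bear on the step taken here.

Compound 4 `CCCCCCCCCO[C@@H]1[C@@H](N)[C@@H](OC[C@H](O)CN)O[C@H](CN)[C@H]1OCCCCCCCCC` is compound 1 with amino in place of azido on a saturated chain carbon, two bonds along the chain from an oxygen on a saturated carbon. Among the measured compounds shown here, no measured step shows this change; the values of compound 1 and compound 3 only show that two compounds of this core both read low. The step is therefore expected to be none beyond the scatter, a number 3.1 percentage points higher from compound 1 to compound 4 (within the scatter). Compound 4 is estimated at 9%, within 0% to 25%.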

Compound 4, a percentage reported as activity, at one concentration (the size of the read-out at that concentration, not a potency): 14.4%
Beside the measured number, compound 4's estimate is 5.4 percentage points below it; low and high end bracket the measured number.
By their numbers in this assay, from the lowest: compounds 1, 3 and 4 (each within the scatter of the next); then compound 2.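

In this assay, among these compounds, amino in place of azido, read as 3-amino-2-hydroxypropyl for 3-azido-2-hydroxypropyl, gives a number 8.5 percentage points higher from compound 1 to compound 4 (within the scatter) and is the first change measured at this position. On the core of compound 1, this position therefore takes the change with no shift beyond the scatter, and the azido group is not required for the low read-out. No evidence on offer accounts for the read-out at this position.

As far as these compounds go, it remains open whether a hydroxyl or a carboxylic acid in place of the amino would also leave the read-out within the scatter. Also open, from the compounds shown here alone, is whether the same change would read alike on compound 2, which gives 66.9% in this assay.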